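Amino for nitro on two triazole cores

A few compounds are considered here, and "the series" means these few. Any claim that something is new, unique, unknown or untested is made for them only; others in the source may bear on it.

Compound 1 `COc1ccc(-c2cnnn2Cc2cc(OC)c(OC)c(OC)c2)cc1[N+](=O)[O-]` and compound 2 `COc1ccc(-c2cnnn2Cc2cc(OC)c(OC)c(OC)c2)cc1N` share one core and differ in one place (amino in place of nitro on an aromatic carbon). In a functional assay on K562 cells (Homo sapiens) for cytotoxicity, read by MTT assay, with a stated time of 5 days (a lower number here means a stronger inhibitor, a higher number a weaker inhibitor), compound 1 gives only a limit, > 10000 nM. Compound 2 gives 380 nM, so the step of an at least 26-fold lower number from compound 1 to compound 2 (1.42 log units; beyond the scatter) is large. Compound 3 `COc1ccc(-c2cn(-c3cc(OC)c(OC)c(OC)c3)nn2)cc1[N+](=O)[O-]` carries a different core; how the two cores differ is not broken down here. In this assay compound 3 also gives only a limit, > 10000 nM. Compound 4 `COc1ccc(-c2cn(-c3cc(OC)c(OC)c(OC)c3)nn2)cc1N` is compound 3 with the same kind of change, (amino in place of nitro on an aromatic carbon). Because (the limit of > 10000 nM in this assay, at which 2 of the 3 values shown sit), the step from compound 3 cannot be measured in full, but a step of about an at least 6.6-fold lower number from compound 3 to compound 4 (0.82 log units; beyond the scatter) is expected, resting on the step seen from compound 1 to compound 2. Compound 4 is therefore estimated at 1500 nM, likely between 300 nM and 10000 nM.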

Compound 4, half-maximal inhibitory concentration: 1300 nM
Compound 4: middle estimate off by 1.2-fold (0.06 log units), on the high side, and the stated range covers the measured number.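

Amino in place of nitro also lowers the number on the second core: in this assay, the change gives an at least 7.6-fold lower number from compound 3 to compound 4 (0.88 log units; beyond the scatter). The direction of the step therefore carries over between these two cores, and the two steps can be set side by side: the same change on two cores in this assay, an at least 26-fold lower number (1.42 log units; beyond the scatter) from compound 1 to compound 2 and an at least 7.6-fold lower number (0.88 log units; beyond the scatter) from compound 3 to compound 4; the limit leaves it open whether they differ. On these data alone, whether the size of the step carries over remains unknown, and the full size of neither step can be read, as compound 1 and compound 3 each give only a limit rather than a number: the limit of > 10000 nM in this assay, at which 2 of the 4 values shown sit.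

The compounds shown leave open whether a hydroxyl or an acetamide on that aromatic carbon would act like amino. They also leave open whether the step would appear on a third core.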